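Replacing the 3,4-dihydroxyphenyl group of compound 3

The source may hold more compounds than are shown below. What is called first, only, known or untested is meant among the compounds shown, and "the series" means these compounds.

Measured in a functional assay on KB cells (Homo sapiens) for antiproliferative activity, read by sulforhodamine B assay, with a stated time of 3 days; on this read-out higher numbers stand for an effect only at larger amounts of compound and lower numbers for an effect already at smaller amounts:
- compound 1 `CCC1=C(O)c2c(oc(-c3ccc(OC)cc3)cc2=O)C(CC)(CC)C1=O`: 17.7 uM
- compound 2 `CCC1=C(O)c2c(oc(-c3ccccc3OC)cc2=O)C(CC)(CC)C1=O`: 40.8 uM
- compound 3 `CCC1=C(O)c2c(oc(-c3ccc(O)c(O)c3)cc2=O)C(CC)(CC)C1=O`: 10 uM

Compound 3 stands level with compound 1 (a 1.8-fold lower number from compound 1 to compound 3 (0.25 log units; within the scatter)) and clearly apart from compound 2 (a 4.1-fold lower number from compound 2 to compound 3 (0.61 log units; beyond the scatter)). All three compounds share one core and differ only in the phenyl group at a single place. Compound 4 `CCC1=C(O)c2c(oc(-c3ccc(O)c(C)c3C)cc2=O)C(CC)(CC)C1=O` changes that same group: 4-hydroxy-2,3-dimethylphenyl in place of 3,4-dihydroxyphenyl (4-hydroxy-2,3-dimethylphenyl in place of 3,4-dihydroxyphenyl on an aromatic carbon).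

Within the data shown here, no measured compound carries methyl groups on this ring, so the data offer only indirect guidance. The closest evidence is the 2-methoxyphenyl group, which also has a substituent numbered 2, and its steps were modest (a 2.3-fold higher number from compound 1 to compound 2 (0.36 log units; beyond the scatter)). The new group shares that numbering with compound 2 (40.8 uM), so a modest rise in the number is expected in this assay. The expected change is a 2.0-fold higher number from compound 3 to compound 4 (0.30 log units; within the scatter). For compound 4 the estimated value is 20 uM, with an expected range from 9 uM to 45 uM.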

Compound 4, concentration for half-maximal effect: 6.5 uM
Beside the measured number, compound 4's estimate is 3.1-fold (0.49 log units) above it; the whole stated range lies above it.
By their numbers in this assay, from the lowest: compounds 4, 3 and 1 (each within the scatter of the next, the first and the last beyond it); then compound 2.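

In this assay, the 4-hydroxy-2,3-dimethylphenyl group can stand in for 3,4-dihydroxyphenyl with no readable change, since the step lies within the scatter (a 1.5-fold lower number from compound 3 to compound 4 (0.19 log units; within the scatter)), so this position accepts methyl groups on the phenyl ring. A substituent numbered 2 does not by itself raise the number, as this group carries one and still stands well below 2-methoxyphenyl (a 6.3-fold lower number from compound 2 to compound 4 (0.80 log units; beyond the scatter)). It also lies below 4-methoxyphenyl (a 2.7-fold lower number from compound 1 to compound 4 (0.44 log units; beyond the scatter)), a gap beyond the scatter that compound 3 did not open.

No measurement here explains these steps. Still open, going by these compounds, is whether either methyl group alone would give the same number, and whether an amine, a carboxylic acid or a longer chain such as propyl on this ring would keep it this low.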